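A few compounds are considered here, and "the series" means these few. Any claim that something is new, unique, unknown or untested is made for them only; others in the source may bear on it.

Compound 1 `CC(C)C(=O)Nc1ccc(S(=O)(=O)Oc2ccccc2I)cc1` and compound 2 `CCCCCNC(=O)Nc1ccc(S(=O)(=O)Oc2ccccc2C(C)C)cc1` make up the measured set. In a functional assay on HT-1080 cells (Homo sapiens) for antiproliferative activity, read by sulforhodamine B assay, with a stated time of 48 h (on this read-out higher numbers stand for weaker inhibition and lower numbers for stronger inhibition), compound 1 gives 3300 nM. In this assay compound 2 gives 4700 nM. Going by the values given here, on these two numbers compound 2 stands alongside compound 1, the gap between them within the usual scatter; the two differ in more than one place, so no single step connects them. Compound 3 `CCCCCNC(=O)Nc1ccc(S(=O)(=O)Oc2ccccc2I)cc1` is not yet measured. It differs from compound 2 by iodo in place of isopropyl on an aromatic carbon. Among the compounds with values here, no measured pair shows this exchange on its own, so the size of the step is open; compound 1, which carries the iodo group, gives 3300 nM in this assay and sits close to compound 2, which suggests no step beyond the scatter. Compound 3 is therefore expected to come out near the two measured numbers, at an estimated 3500 nM with a range from 1500 nM to 8500 nM. The expected step is a 1.3-fold lower number from compound 2 to compound 3 (0.13 log units; within the scatter), within the scatter.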

Compound 3, half-maximal inhibitory concentration: 6900 nM
Compound 3: middle estimate off by 2.0-fold (0.29 log units), on the low side, within the range that was stated.
By their numbers in this assay, from the lowest: compounds 1, 2 and 3 (each within the scatter of the next, the first and the last beyond it).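

In this assay the exchange of isopropyl for iodo on this aromatic carbon can now be read directly as a 1.5-fold higher number from compound 2 to compound 3 (0.17 log units; within the scatter) and so does not move the number beyond the scatter in the pentylamino series. Going by these compounds alone, with the iodo group held fixed, pentylamino in place of isopropyl on a carbonyl carbon gives a 2.1-fold higher number from compound 1 to compound 3 (0.32 log units; beyond the scatter) and is the only single change so far beyond the scatter, though modest in size. No supporting data explain either step.

Going by these compounds, whether an amine or a carboxylic acid on this aromatic carbon would give a larger step remains open. Also open, on these data alone, are the effect of a longer chain than pentylamino on the carbonyl carbon and whether the iodo and isopropyl exchange reads the same with isopropyl on the carbonyl carbon.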